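Lengthening the amine chain of compound 3

This account rests on a few compounds, and the source may have more. Where it says the series, first, only, none or still open, it means among the compounds named here.

In a functional assay on HL60/MX2 cells (Homo sapiens) for antiproliferative activity, read by MTT assay, with a stated time of 48 h (on this read-out higher numbers stand for weaker inhibition and lower numbers for stronger inhibition), compound 1 `CN(C)CCn1c(N)c(-c2nc3ccccc3[nH]2)c2nc(C#N)c(C#N)nc21` gives 3780 nM. Compound 2 `CN(C)CCn1c(N)c(-c2nc3ccccc3s2)c2nc(C#N)c(C#N)nc21` reaches only a limit of the assay, > 50000 nM. Compound 3 `CN(C)CCn1c(N)c(-c2nc3ccccc3n2C)c2nc(C#N)c(C#N)nc21`, at 4680 nM, lies within the scatter of compound 1. Compound 4 `CN(C)CCCCn1c(N)c(-c2nc3ccccc3n2C)c2nc(C#N)c(C#N)nc21` differs from compound 3 by 2-(dimethylamino)ethyl in place of dimethylamino on a saturated chain carbon, two bonds along the chain from an aromatic nitrogen. Neither the large step of an at least 13-fold higher number from compound 1 to compound 2 (1.12 log units; beyond the scatter) nor the step of a 1.2-fold higher number from compound 1 to compound 3 (0.09 log units; within the scatter), which lies within the scatter, touches that chain, so no step beyond the scatter is expected in this assay. The expected change is a 1.0-fold lower number from compound 3 to compound 4 (0.02 log units; within the scatter). For compound 4 the estimated value is 4500 nM, with an expected range of 1500 nM to 14000 nM.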

Compound 4, half-maximal inhibitory concentration: 2580 nM
The estimate for compound 4 lay 1.7-fold (0.24 log units) above the measured number; low and high end bracket the measured number.
By their numbers in this assay, from the lowest: compounds 4, 1 and 3 (each within the scatter of the next). At a limit, above all of these: compound 2.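

In this assay, 4-(dimethylamino)butyl in place of 2-(dimethylamino)ethyl gives a 1.8-fold lower number from compound 3 to compound 4 (0.26 log units; within the scatter). Within the data shown here, the earlier steps left this chain untouched, so only this step shows that the longer chain is accommodated here with no change beyond the scatter. Nothing given here explains this step.

On these data alone, whether 3-(dimethylamino)propyl, a still longer chain or a morpholine in place of the dimethylamino group would also stay within the scatter remains open. So does whether the same lengthening would read alike with the 1H-benzimidazol-2-yl group of compound 1.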